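From methyl to cyclopentyl on an aromatic-ring nitrogen

The source may hold more compounds than are shown below. What is called first, only, known or untested is meant among the compounds shown, and "the series" means these compounds.

Compound 1, `CC(C)N(C)c1nc2ccc(NC(=O)CCc3ccc(C(F)(F)F)cc3)cc2[nH]1`, in an assay on CHO-K1 cells for displacement of a labelled ligand from melanin-concentrating hormone receptor 1 (Homo sapiens), read by scintillation counting; on this read-out higher numbers stand for weaker inhibition and lower numbers for stronger inhibition: 5.9 nM
Compound 2, `CN(C)c1nc2ccc(NC(=O)CCc3ccc(C(F)(F)F)cc3)cc2[nH]1`, in this assay: 12 nM

Of the compounds shown here, two have been measured, and compound 2 gives the higher of the two numbers in this assay; the only neighbour is compound 1, whose step a 2.0-fold higher number from compound 1 to compound 2 (0.31 log units; beyond the scatter) shows that swapping isopropyl for methyl on the nitrogen on the aromatic ring raised the number modestly, beyond the scatter. Compound 3, `CN(c1nc2ccc(NC(=O)CCc3ccc(C(F)(F)F)cc3)cc2[nH]1)C1CCCC1`, has not yet been measured. It differs from compound 2 in one place: cyclopentyl in place of methyl on a nitrogen on an aromatic ring. Among the compounds with values here, the one step that bears on this change is a 2.0-fold higher number from compound 1 to compound 2 (0.31 log units; beyond the scatter), which runs in the opposite direction, from a larger group to a smaller one, and was modest in size. Going from methyl to the larger cyclopentyl is therefore expected to lower the number, by roughly the size of that step or a little more, so the estimated step is a 3.0-fold lower number from compound 2 to compound 3 (0.48 log units; beyond the scatter). For compound 3 the expected value in this assay is 4 nM, with a range from 1.5 nM to 12 nM.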

Compound 3, half-maximal inhibitory concentration: 4 nM
Beside the measured number, compound 3's estimate shows no gap at the digits printed, and the stated range covers the measured number.
By their numbers in this assay, from the lowest: compounds 3 and 1 (each within the scatter of the next); then compound 2.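

In this assay, cyclopentyl, which brings a five-membered ring of carbon only onto the nitrogen on an aromatic ring, gives a 3.0-fold lower number from compound 2 to compound 3 (0.48 log units; beyond the scatter) and so shows that this place accepts a ring as well as the open isopropyl group. Both of these groups now give lower numbers than methyl, so the trend in compound 1 and compound 2 holds for a second, larger group. Against isopropyl, however, cyclopentyl gives a 1.5-fold lower number from compound 1 to compound 3 (0.17 log units; within the scatter) and that step lies within the scatter, so the two groups cannot be told apart here and the added size shows no further effect, while no measurement is available to explain any of these steps.

Still open, as far as these compounds go, is whether a cyclobutyl or cyclohexyl ring, or a longer chain such as n-butyl, would keep the number as low on this nitrogen. The methyl that stays on the same nitrogen in compound 1 and compound 3 also leaves open what a hydrogen or an ethyl in its place would do.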